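Benzyl to cyclohexyl on the amine of compound 3

A few compounds are considered here, and "the series" means these few. Any claim that something is new, unique, unknown or untested is made for them only; others in the source may bear on it.

Compound 3 `O=C1C=C(NCc2ccccc2)C(=O)c2c1nc1n2[C@H]2OC[C@@H](O)[C@H]2OC1` is the highest of the two numbers in hand from a functional assay on MGC-803 cells (Homo sapiens) for inhibition, read by sulforhodamine B assay; on this read-out lower numbers stand for stronger inhibition and higher numbers for weaker inhibition: compound 3 gives 2670 nM. Its nearest neighbour, compound 1 `COc1cccc(NC2=CC(=O)c3c(nc4n3[C@H]3OC[C@@H](O)[C@H]3OC4)C2=O)c1`, gives 1790 nM, which lies within the scatter of compound 3. Compound 2 `O=C1C(N2CCCCC2)=CC(=O)c2c1nc1n2[C@H]2OC[C@@H](O)[C@H]2OC1` returned only a limit of this assay, > 4000 nM, so no number stands for it. For the measured compounds named here, the single measured step, an at least 2.2-fold higher number from compound 1 to compound 2 (0.34 log units; beyond the scatter), replaces an aryl amine by a saturated ring bound through its nitrogen and ends at the limit (the limit of > 4000 nM in this assay, at which 1 of the 3 values shown sits).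

Compound 4 `O=C1C=C(NC2CCCCC2)C(=O)c2c1nc1n2[C@H]2OC[C@@H](O)[C@H]2OC1` carries cyclohexyl in place of benzyl on an amine nitrogen. Compared with compound 3, the aromatic ring is gone and a saturated ring of the same size takes its place, while the amine hydrogen stays. The step from compound 1 to compound 2 also trades an aromatic substituent for a saturated one and moved the number up; on that basis a modest rise, toward weaker inhibition, is expected here, with a fair chance that only a limit is reported. Compound 4 is therefore estimated at 3800 nM, between 1600 nM and 9000 nM, corresponding to an expected 1.4-fold higher number from compound 3 to compound 4 (0.15 log units; within the scatter).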

Compound 4, half-maximal inhibitory concentration: > 8000 nM
Compound 4 ended at the assay's limit; the forecaster's own chance of this, stated with the estimate: 40%; middle value at least 2.1-fold (0.32 log units) from the limit.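

In this assay, cyclohexyl in place of benzyl on an amine nitrogen gives an at least 2.9-fold higher number from compound 3 to compound 4 (0.47 log units; beyond the scatter), with the amine hydrogen kept. The earlier step, an at least 2.2-fold higher number from compound 1 to compound 2 (0.34 log units; beyond the scatter), lost that hydrogen together with the aromatic ring and could not separate the two changes, whereas here the swap of aromatic for saturated ring stands alone and the number still rises. Compound 4 gives a limit and not a number, so the full size of this step cannot be read: the limit of > 8000 nM in this assay, at which 1 of the 4 values shown sits.

Both steps point the same way, but two steps fix no rule for the series. Open, going by these compounds, is whether an aromatic ring on this amine nitrogen is what matters, which a pyridin-3-ylmethyl group or a straight hexyl chain in the place of benzyl would test.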